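The compounds below may be only part of what the source reports. "The series", "measured", "known", "first", "only" and "open" are said of these compounds alone.

In a toxicity assay on NIH3T3 cells (Mus musculus) for cytotoxicity, read by resazurin assay (on this read-out lower numbers stand for an effect already at smaller amounts and higher numbers for an effect only at larger amounts of compound), compound 1 (`COC(=O)c1ccc(NCc2cncn2Cc2ccc(Cl)cc2)cc1-c1ccccc1`) gives a measured number, 25000 nM. Compound 2 (`c1ccc(-c2ccc(Cn3cncc3CNc3ccc(-c4nc5ccccc5s4)c(-c4ccccc4)c3)cc2)cc1`) returns only a limit, > 1000 nM. Compound 3 (`CC(C)c1ccc(Cn2cncc2CNc2ccc(-c3nc4ccccc4s3)c(-c3ccccc3)c2)cc1`) also returns only a limit, > 1000 nM. Compound 3 therefore has no number of its own and stands with compound 2 at the limit of > 1000 nM in this assay, at which 2 of the 3 values shown sit.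

Compound 4 (`Clc1ccc(Cn2cncc2CNc2ccc(-c3nc4ccccc4s3)c(-c3ccccc3)c2)cc1`) differs from compound 3 by one change, 4-isopropylbenzyl to 4-chlorobenzyl: chloro in place of isopropyl on an aromatic carbon. Among the measured compounds shown here, the one measured step that bears on this position is a step that the two limits leave unreadable from compound 2 to compound 3. It replaces a group at the same place, but it gives no size that could be carried over.

For the measured compounds named here, compound 1 is the only measured compound with a 4-chlorobenzyl group, and it has a different core, so its 25000 nM is only a loose guide. With so little to go on, no change beyond the scatter can be predicted in either direction, and compound 4 may again be reported only as a limit. The expected outcome is a step that the limit leaves unreadable from compound 3 to compound 4, with no direction foreseen. Compound 4 is estimated at 3000 nM, with an expected range from 1000 nM to 20000 nM.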

Compound 4, half-maximal effective concentration: > 1000 nM
Compound 4 ended at the assay's limit; the forecaster's own chance of this, stated with the estimate: 70%; the middle value does not contradict the limit.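

In this assay compound 4 returns only a limit, > 1000 nM. No step to compound 4 from compound 1, compound 2 or compound 3 can be read, and compound 4 joins compound 2 and compound 3: the limit of > 1000 nM in this assay, at which 3 of the 4 values shown sit.

The compounds shown leave open whether phenyl, isopropyl or chloro at this place differ at all in this assay.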